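The source may hold more compounds than are shown below. What is called first, only, known or untested is meant among the compounds shown, and "the series" means these compounds.

Compound 2 `CC1CC(=O)N(c2ccccc2C(=O)OCC2CCCN(CCCCOc3ccccc3)C2)C1=O` is the lower of the two numbers recorded in an in vitro functional assay on HEK ts201 cells for antagonist activity at Neuronal acetylcholine receptor; alpha4/beta2 (Homo sapiens), read by fluorescence and calcium flux; a lower number here means a stronger inhibitor, a higher number a weaker inhibitor: compound 2 gives 1700 nM, while compound 1 `CC1CC(=O)N(c2ccccc2C(=O)OCC2CCCN(CCCCCc3ccccc3)C2)C1=O` gives 24500 nM. Among the compounds with values here, the one measured step, a 14-fold lower number from compound 1 to compound 2 (1.16 log units; beyond the scatter), concerns an exchange of phenoxy for benzyl. Compound 3 `CC1CC(=O)N(c2ccccc2C(=O)OCC2CCCN(CCCCCOc3ccc(Cl)c(Cl)c3)C2)C1=O` is compound 2 altered in one place: (3,4-dichlorophenoxy)methyl in place of phenoxy on a saturated chain carbon, four bonds along the chain from an amine nitrogen in a ring. Within the data shown here, this change bears no direct resemblance to the measured step, since the aromatic ring now carries two chlorines and is reached through a chain one carbon longer, and no recorded pair isolates either of those alterations. Among the measured compounds shown here, the only guidance is that the ether-linked ring in compound 2 sits at the lower end of the pair, so keeping that ether while extending the chain and adding chlorines is expected to change the number only modestly, in either direction. Compound 3 is therefore estimated at 1500 nM in this assay, within 300 nM to 8000 nM, a step of a 1.1-fold lower number from compound 2 to compound 3 (0.05 log units; within the scatter) that is expected to be small relative to the measured one.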

Compound 3, half-maximal inhibitory concentration: 17400 nM
Compound 3: middle estimate off by 12-fold (1.06 log units), on the low side; the whole stated range lies below it.
By their numbers in this assay, from the lowest: compound 2; then compounds 3 and 1 (each within the scatter of the next).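

In this assay, keeping an ether-linked ring does not by itself preserve the lower number: placing (3,4-dichlorophenoxy)methyl in place of phenoxy at this position gives a 10-fold higher number from compound 2 to compound 3 (1.01 log units; beyond the scatter), opposite in direction to a 14-fold lower number from compound 1 to compound 2 (1.16 log units; beyond the scatter). Compound 3 keeps the ether oxygen that compound 1 lacks, yet the comparison between them gives a 1.4-fold lower number from compound 1 to compound 3 (0.15 log units; within the scatter), so the oxygen does not separate this pair. Nothing recorded here accounts for the reversal.

The change combines two chlorines with an extra chain carbon, and the compounds shown do not tell which of these goes with the higher number. Open too, from the compounds shown here alone, is how 3,4-dichlorophenoxy would read on the shorter chain of compound 2, and how 3,4-difluorophenoxy or unsubstituted phenoxy would read on the longer chain of compound 3.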